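The source may hold more compounds than are shown below. What is called first, only, known or untested is meant among the compounds shown, and "the series" means these compounds.

Measured compounds:
compound 1, `COc1ccc(-c2cc3ccccc3nc2/C=C/C(=O)c2c(OC)cccc2OC)cc1`, in a functional assay on SK-BR-3 cells (Homo sapiens) for antiproliferative activity, read by XTT assay, with a stated time of 72 h (a lower number here means a stronger inhibitor, a higher number a weaker inhibitor), compound 1 gives 3830 nM.
compound 2, `COc1ccc(-c2cc3ccccc3nc2/C=C/C(=O)c2ccc(Br)s2)cc1`, in this assay compound 2 gives 520 nM.

Among the measured compounds shown here, compound 2 holds the lowest of the two numbers, with compound 1 its only neighbour, and the single measured step, a 7.4-fold lower number from compound 1 to compound 2 (0.87 log units; beyond the scatter), separates the two. Compound 3, `COc1ccc(-c2cc3ccccc3nc2/C=C/C(=O)c2ccsc2)cc1`, is the unmeasured member: thiophen-3-yl in place of 5-bromothiophen-2-yl on a carbonyl carbon. For the measured compounds named here, no measured step exchanges one thiophene for another on the carbonyl carbon, so only the step from compound 1 to compound 2 bears on it, and it shows that the group on the carbonyl carbon can move the number by a modest amount in either direction. A step of similar size, toward a higher number, is therefore expected in this assay for compound 3, though a result within the scatter cannot be ruled out. The estimated step is a 2.9-fold higher number from compound 2 to compound 3 (0.46 log units; beyond the scatter). Compound 3 is expected to give about 1500 nM, within 500 nM to 5000 nM.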

Compound 3, half-maximal inhibitory concentration: 660 nM
For compound 3 the middle estimate is 2.3-fold (0.36 log units) above the measured one, within the range that was stated.
By their numbers in this assay, from the lowest: compounds 2 and 3 (each within the scatter of the next); then compound 1.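

In this assay, thiophen-3-yl on the carbonyl carbon gives a 1.3-fold higher number from compound 2 to compound 3 (0.10 log units; within the scatter), so this position does not separate the two thiophene groups, although only 5-bromothiophen-2-yl carries a bromine. The second new step, a 5.8-fold lower number from compound 1 to compound 3 (0.76 log units; beyond the scatter), is close in reading to the earlier 7.4-fold lower number from compound 1 to compound 2 (0.87 log units; beyond the scatter), which shows that the lower number relative to 2,6-dimethoxyphenyl is not confined to the brominated thiophene among these three compounds. Nothing available explains these numbers.

The compounds shown do not separate the loss of the bromine from the change between a thiophen-2-yl and a thiophen-3-yl group, as the single step combines both. Also open, going by these compounds, is how a thiophene carrying an amine or a carboxylic acid would read at this position in this assay.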